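The compounds below may be only part of what the source reports. "The series", "measured", "known", "first", "only" and "open" are said of these compounds alone.

The study concerns a shared core carrying an amino group and a nitro group, varied at one aromatic carbon. Compound 1 `Nc1nn2c(O)cc(-c3ccccc3)nc2c1[N+](=O)[O-]` bears a phenyl there. In a functional assay on L929 cells (Mus musculus) for inhibition (on this read-out higher numbers stand for weaker inhibition of growth and lower numbers for stronger inhibition of growth), compound 1 gives > 50 ug/mL, which is a limit of the assay and not a number. Compound 2 `Nc1nn2c(O)cc(CNNCCO)nc2c1[N+](=O)[O-]` carries a (((2-hydroxyethyl)amino)amino)methyl in place of phenyl on an aromatic carbon. In this assay compound 2 gives > 50 ug/mL, again a limit. The step that the two limits leave unreadable from compound 1 to compound 2 is therefore unreadable. Compound 3 `Nc1nn2c(O)cc(CNC(N)SCc3ccccc3)nc2c1[N+](=O)[O-]` is the third member. In this assay compound 3 gives > 50 ug/mL, once more a limit. Compound 3 thus stands where every value shown sits, namely (the limit of > 50 ug/mL in this assay, at which 3 of the 3 values shown sit). Compound 4 `CCSC(N)NCc1cc(O)n2nc(N)c([N+](=O)[O-])c2n1` differs from compound 3 by methyl in place of phenyl on a saturated chain carbon bound to a sulfur. Among the measured compounds shown here, the only measured step is unreadable, so no step of any size in this assay can be inferred for this change, and no shift beyond the scatter is expected. Compound 4 is expected to give 60 ug/mL, within a range from 30 ug/mL to 150 ug/mL. This expectation corresponds to a step that the limit leaves unreadable from compound 3 to compound 4 in this assay, and most likely another limit.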

Compound 4, concentration for 50% growth inhibition: > 50 ug/mL
Compound 4: a limit, no number; the forecaster's own chance of this, stated with the estimate: 80%; the middle value is on the limit's open side.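

In this assay, among the compounds shown here, compound 4 gives a limit and not a number, as do compound 1, compound 2 and compound 3, so no step to compound 4 can be read. The compounds shown leave open how strongly any of them inhibits growth, because all sit at the same limit: the limit of > 50 ug/mL in this assay, at which 4 of the 4 values shown sit.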